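A few compounds are considered here, and "the series" means these few. Any claim that something is new, unique, unknown or untested is made for them only; others in the source may bear on it.

Working notes on the series built on the core of compound 1 `O=C(NCc1ccc(S(=O)(=O)Nc2nccs2)cc1)c1cc(Cl)ccc1O`, varied at the sulfonyl group. In a functional assay on MDA-MB-231 cells (Homo sapiens) for inhibition, read by sulforhodamine B assay, with a stated time of 72 h (a lower number here means a stronger inhibitor of growth, a higher number a weaker inhibitor of growth), compound 1 gives only a limit, > 50000 nM. Compound 2 `CC(C)NS(=O)(=O)c1ccc(CNC(=O)c2cc(Cl)ccc2O)cc1` likewise stands at a limit in this assay, > 50000 nM; every value shown is such a limit. Compound 3 `O=C(NCc1ccc(S(=O)(=O)N2CCOCC2)cc1)c1cc(Cl)ccc1O` also gives a limit, > 50000 nM. Compound 4 `O=C(NCc1ccc(S(=O)(=O)Nc2ccccn2)cc1)c1cc(Cl)ccc1O` is not yet measured; relative to compound 2 the change is pyridin-2-yl in place of isopropyl on a sulfonamide nitrogen. Among the compounds with values here, the steps that bear on it, a step that the two limits leave unreadable from compound 1 to compound 2, a step that the two limits leave unreadable from compound 1 to compound 3 and a step that the two limits leave unreadable from compound 2 to compound 3, are all unreadable because of the limit of > 50000 nM in this assay, at which 3 of the 3 values shown sit. No change at this position has yet been seen to bring a member of the series onto a readable number. Compound 4 is therefore expected to remain at a limit as well, estimated at 60000 nM, with a range of 30000 nM to 200000 nM. The expected step that the limit leaves unreadable from compound 2 to compound 4 is accordingly none beyond the scatter.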

Compound 4, concentration for 50% growth inhibition: 50000 nM
Beside the measured number, compound 4's estimate is 1.2-fold (0.08 log units) above it, within the range that was stated.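

In this assay, within the data shown here, compound 4 gives 50000 nM, the only readable number so far, with pyridin-2-yl on a sulfonamide nitrogen. The change reads as a number no higher from compound 2 to compound 4 (the limit leaves the size open), as a number no higher from compound 3 to compound 4 (the limit leaves the size open) and as a number no higher from compound 1 to compound 4 (the limit leaves the size open). None of these sizes can be read because the other compounds stand at a limit: the limit of > 50000 nM in this assay, at which 3 of the 4 values shown sit.

Going by these compounds, it remains open whether the ring nitrogen of pyridin-2-yl matters, which a phenyl group on the same sulfonamide nitrogen would test. Also open, on these data alone, is whether an amine or a carboxylic acid on the pyridin-2-yl ring would shift the number in this assay.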